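Swapping a Nitrile Arm for a Bromophenyl in a Tolerated Series

A few compounds are considered here, and "the series" means these few. Any claim that something is new, unique, unknown or untested is made for them only; others in the source may bear on it.

Three close relatives share one core and differ only in the group on the amide carbonyl. Compound 1 `COc1ccc(-c2cnc(NC(=O)c3ccccc3OC)n2C)cc1` carries a 2-methoxyphenyl there. In a toxicity assay on THP-1 cells (Homo sapiens) for inhibition (a lower number here means that less compound is tolerated, a higher number that more compound is tolerated), compound 1 reaches only the assay limit, > 100000 nM. Compound 2 `COc1ccc(-c2cnc(NC(=O)CCc3ccccc3)n2C)cc1` carries a phenethyl instead. In this assay compound 2 also stops at the limit, > 100000 nM. Compound 3 `COc1ccc(-c2cnc(NC(=O)c3cccc(C#N)c3)n2C)cc1` carries a 3-cyanophenyl. In this assay compound 3 likewise stands at the limit, > 100000 nM. Compound 3 therefore sits at the limit of > 100000 nM in this assay, at which 3 of the 3 values shown sit, and the steps a step that the two limits leave unreadable from compound 1 to compound 2, a step that the two limits leave unreadable from compound 1 to compound 3 and a step that the two limits leave unreadable from compound 2 to compound 3 cannot be sized. Compound 4 `COc1ccc(-c2cnc(NC(=O)c3ccccc3Br)n2C)cc1` is not yet measured; its change from compound 3 is 2-bromophenyl in place of 3-cyanophenyl on a carbonyl carbon. Every measured swap on this carbon left the value at the limit of > 100000 nM in this assay, at which 3 of the 3 values shown sit. Across this change the expected step is a number no higher from compound 3 to compound 4 (the limit leaves the size open), none beyond the scatter. Compound 4 is estimated at 100000 nM, within 40000 nM to 300000 nM.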

Compound 4, half-maximal cytotoxic concentration: > 100000 nM
Compound 4: only a limit was reported (the forecaster's own chance of this, stated with the estimate: 85%); the middle value sits exactly at the limit.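

Compound 4 also stops at a limit, so its steps from compound 1, compound 2 and compound 3 cannot be read: the limit of > 100000 nM in this assay, at which 4 of the 4 values shown sit. The compounds shown leave open how much compound is actually tolerated in this assay, and whether any of these groups on the carbonyl carbon changes that.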